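Acetyl to Propanoyl on a Second Sulfonamide Core

The compounds below may be only part of what the source reports. "The series", "measured", "known", "first", "only" and "open" are said of these compounds alone.

Compound 1 `CC(=O)N1CCN(S(=O)(=O)c2ccc(F)cc2)C1` and compound 2 `CCC(=O)N1CCN(S(=O)(=O)c2ccc(F)cc2)C1` share one core. In a functional assay on the whole organism with Mus musculus as the target (a higher number here means that more compound is needed for the effect, a lower number that less compound is needed), compound 1 gives 1 mg/kg, and compound 2 gives 1 mg/kg. The change between them, (methyl in place of hydrogen on a saturated chain carbon bound to a carbonyl carbon), produced no change at the digits printed from compound 1 to compound 2 (within the scatter). Compound 3 `CC(=O)N1CCCN(S(=O)(=O)c2ccc(F)cc2)C1` rests on a second core; how the two cores differ is not broken down here. In this assay compound 3 gives 1 mg/kg, level with compound 1 and compound 2. Compound 4 `CCC(=O)N1CCCN(S(=O)(=O)c2ccc(F)cc2)C1` carries the same change on the core of compound 3: methyl in place of hydrogen on a saturated chain carbon bound to a carbonyl carbon. Because no change at the digits printed from compound 1 to compound 2 (within the scatter) lay within the scatter, the expected step in this assay is no change at the digits printed from compound 3 to compound 4 (within the scatter). Compound 4 is therefore estimated at 1 mg/kg, with a likely range from 0.5 mg/kg to 2 mg/kg.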

Compound 4, minimum effective dose: 1 mg/kg
Beside the measured number, compound 4's estimate shows no gap at the digits printed; low and high end bracket the measured number.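

In this assay the acetyl to propanoyl change on the core of compound 3 gave no change at the digits printed from compound 3 to compound 4 (within the scatter). Set beside the earlier step, the change reads the same on both cores: the same change on two cores in this assay, no change at the digits printed (within the scatter) from compound 1 to compound 2 and no change at the digits printed (within the scatter) from compound 3 to compound 4, 1.0-fold (0.00 log units) apart, within the scatter of two such steps. This shows that, for these two pairs, the step carried from one core to the other without a visible difference, but both steps lie within the scatter, so it does not show that a step beyond the scatter would carry over, nor does it speak for any further core.

The compounds shown leave open how a longer chain or a branched chain such as isopropyl would read in this assay. On these data alone, an amine on the saturated chain carbon bound to the carbonyl carbon also remains open.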